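Methoxy for Methyl on the Aryl Triazole Furanone

This account rests on a few compounds, and the source may have more. Where it says the series, first, only, none or still open, it means among the compounds named here.

Measured compounds:
Compound 1 `Cc1ccc(-c2cn(C/C=C3\OC(=O)C(OCc4ccccc4)=C3OCc3ccccc3)nn2)cc1` gives 7480 nM in a functional assay on HeLa cells (Homo sapiens) for antiproliferative activity, read by MTT assay, with a stated time of 72 h; a lower number here means a stronger inhibitor, a higher number a weaker inhibitor.
Compound 2 `CCCCc1cn(C[C@H](O)[C@H]2OC(=O)C(OCc3ccccc3)=C2OCc2ccccc2)nn1` gives 18100 nM in this assay.
Compound 3 `COc1ccccc1-c1cn(C[C@H](O)[C@H]2OC(=O)C(OCc3ccccc3)=C2OCc2ccccc2)nn1` reaches only the limit > 100000 nM in this assay.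

Compound 1 holds the lowest of the two numbers, and compound 2 sits higher. Compound 3 is a limit, not a number, as the limit of > 100000 nM in this assay, at which 1 of the 3 values shown sits, records. Compound 4 `COc1ccc(-c2cn(C/C=C3\OC(=O)C(OCc4ccccc4)=C3OCc3ccccc3)nn2)cc1` differs from compound 1 by methoxy in place of methyl on an aromatic carbon. Among the measured compounds shown here, the only measured step, an at least 5.5-fold higher number from compound 2 to compound 3 (0.74 log units; beyond the scatter), swaps a butyl for a 2-methoxyphenyl and bears on this change only loosely. For the measured compounds named here, no measured step tells what methyl to methoxy does here, so a step within the scatter is expected, a 1.2-fold higher number from compound 1 to compound 4 (0.08 log units; within the scatter). Compound 4 is therefore estimated at 9000 nM, between 3500 nM and 25000 nM.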

Compound 4, half-maximal inhibitory concentration: > 100000 nM
Compound 4 was reported as a limit; the forecaster's own chance of this, stated with the estimate: 5%; middle value at least 11-fold (1.04 log units) from the limit.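

The swap of 4-methylphenyl for 4-methoxyphenyl brings an at least 13-fold higher number from compound 1 to compound 4 (1.12 log units; beyond the scatter) in this assay, so this position, para to a large group, is sensitive to even a small change: the entering methoxy adds only one oxygen to the methyl it replaces. The reading for compound 4 is a limit and not a number, so the full size of the step stays unknown: the limit of > 100000 nM in this assay, at which 2 of the 4 values shown sit.

From the compounds shown here alone, whether a chlorine, an ethyl or a hydroxyl at this position would stay close to compound 1 or also reach the limit remains open. So does whether the same swap would have a comparable effect on the core of compound 2.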